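The compounds below may be only part of what the source reports. "The series", "measured", "known", "first", "only" and "open" are said of these compounds alone.

Measured in a functional assay on HL-60 cells (Homo sapiens) for antiproliferative activity, read by CCK-8 assay, with a stated time of 72 h; on this read-out higher numbers stand for weaker inhibition and lower numbers for stronger inhibition:
- Compound 1 `CC(=O)Oc1cc2c(CC[C@H](O)C(C)(C)O)c(C)ccc2cc1C(C)C`: 21700 nM
- Compound 2 `CC(=O)Oc1cc2c(CC[C@@H](O)C(C)(C)O)c(C)ccc2cc1C(C)C`: 41200 nM

Going by the values given here, compound 2 stands level with the only other measured compound, as the sole measured step shows: a 1.9-fold higher number from compound 1 to compound 2 (0.28 log units; within the scatter). That step reflects (the fact that compounds 1 and 2 differ only in the configuration as drawn), so it says little about a change of group.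

Compound 3 `CC(=O)Oc1cc2c(CC[C@@H]3OC(C)(C)OC3(C)C)c(C)ccc2cc1C(C)C` differs from compound 2 as follows: 2,2,5,5-tetramethyl-1,3-dioxolan-4-yl in place of 1,2-dihydroxy-2-methylpropyl on a saturated chain carbon, two bonds along the chain from an aromatic carbon. Among the compounds with values here, no measured step covers a change of this kind, so no shift beyond the scatter is expected in this assay, though the uncertainty is wide. The estimated step is a 1.6-fold lower number from compound 2 to compound 3 (0.22 log units; within the scatter). For compound 3 the expected value is 25000 nM, with an estimated range of 7000 nM to 80000 nM.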

Compound 3, half-maximal inhibitory concentration: 16000 nM
Compound 3: middle estimate off by 1.6-fold (0.19 log units), on the high side, within the range that was stated.
By their numbers in this assay, from the lowest: compounds 3, 1 and 2 (each within the scatter of the next, the first and the last beyond it).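

In this assay, putting 2,2,5,5-tetramethyl-1,3-dioxolan-4-yl, with 0 hydrogen-bond donors, in place of 1,2-dihydroxy-2-methylpropyl gives a 2.6-fold lower number from compound 2 to compound 3 (0.41 log units; beyond the scatter), a modest shift, and a 1.4-fold lower number from compound 1 to compound 3 (0.13 log units; within the scatter). In these compounds, then, activity at this level does not depend on free hydroxyl groups on this chain. The same change reads beyond the scatter from one starting point and within it from the other, and these two starting points are closely related: the fact that compounds 1 and 2 differ only in the configuration as drawn

Going by these compounds, whether the ring itself or the loss of the hydroxyl groups matters remains open. A methyl ether or an amine on this saturated chain carbon could help separate the two.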